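Thiophen-3-yl for 1,3-thiazol-5-yl on the amide carbonyl

A few compounds are considered here, and "the series" means these few. Any claim that something is new, unique, unknown or untested is made for them only; others in the source may bear on it.

In a functional assay on MKN-74 cells (Homo sapiens) for inhibition, read by colorimetric assay and sulforhodamine B assay, with a stated time of 48 h (a lower number here means a stronger inhibitor of growth, a higher number a weaker inhibitor of growth), compound 1 `CCCCCCCCCCCC[C@@H](O)[C@H]1CC[C@H]([C@H](O)CCCCCCCCCCNC(=O)c2cccs2)O1` reads 1510 nM and compound 2 `CCCCCCCCCCCC[C@@H](O)[C@H]1CC[C@H]([C@H](O)CCCCCCCCCCNC(=O)c2ccoc2)O1` reads 21900 nM, while compound 3 `CCCCCCCCCCCC[C@@H](O)[C@H]1CC[C@H]([C@H](O)CCCCCCCCCCNC(=O)c2cncs2)O1` reads 61700 nM as the highest of the three numbers. Compound 4 `CCCCCCCCCCCC[C@@H](O)[C@H]1CC[C@H]([C@H](O)CCCCCCCCCCNC(=O)c2ccsc2)O1` carries thiophen-3-yl in place of 1,3-thiazol-5-yl on a carbonyl carbon. For the measured compounds named here, three measured steps bear on this change. Thiophen-2-yl to 1,3-thiazol-5-yl was the largest (a 41-fold higher number from compound 1 to compound 3 (1.61 log units; beyond the scatter)), furan-3-yl in place of thiophen-2-yl was also large (a 15-fold higher number from compound 1 to compound 2 (1.16 log units; beyond the scatter)), and 1,3-thiazol-5-yl in place of furan-3-yl was modest (a 2.8-fold higher number from compound 2 to compound 3 (0.45 log units; beyond the scatter)). The step to compound 4 leaves the group that sits at the top of the numbers, and it enters a thiophen group, a ring type measured so far only as thiophen-2-yl. A sizeable drop in the number is therefore expected in this assay, though probably not the full way back to compound 1 at 1510 nM in this estimate. The expected change is a 12-fold lower number from compound 3 to compound 4 (1.09 log units; beyond the scatter) on this reasoning. Compound 4 is estimated at 5000 nM within a range of 1300 nM to 20000 nM for now.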

Compound 4, concentration for 50% growth inhibition: 1510 nM
Beside the measured number, compound 4's estimate is 3.3-fold (0.52 log units) above it; measured number inside the range.
By their numbers in this assay, from the lowest: compounds 1 and 4 (each within the scatter of the next); then compound 2; then compound 3.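

In this assay, thiophen-3-yl on the amide carbonyl gives a 41-fold lower number from compound 3 to compound 4 (1.61 log units; beyond the scatter) and a 15-fold lower number from compound 2 to compound 4 (1.16 log units; beyond the scatter), so a thiophen ring on this carbonyl is not limited to its 2-yl form in reaching the low end of the series. Thiophen-3-yl in place of thiophen-2-yl gives no change at the digits printed from compound 1 to compound 4 (within the scatter), so the two thiophen isomers cannot be told apart here, while the single ring nitrogen of 1,3-thiazol-5-yl separates compound 3 from compound 4 by a large step. The data shown give no measured reason for these steps.

Going by these compounds, it remains open whether a phenyl or pyridin-3-yl ring on the same carbonyl would read with the two thiophens or with compound 2 and compound 3. Also open, on these data alone, is whether a methyl or chloro group on the thiophen ring would keep the number at the level of compound 1 and compound 4.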